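The compounds below may be only part of what the source reports. "The series", "measured", "known", "first", "only" and "open" are said of these compounds alone.

Compound 1 `CC(=O)NCc1cccc(Cn2nc(NS(=O)(=O)c3ccc(Cl)s3)c3ccccc32)c1` and compound 2 `CC(=O)NCc1cccc(Cn2nc(NS(=O)(=O)c3ccc(Cl)s3)c3c(Cl)cccc32)c1` share one core; compound 3 `COc1cccc2c1c(NS(=O)(=O)c1ccc(Cl)c(Cl)c1)nn2Cc1cccc(CNC(=O)C(C)(C)O)c1` and compound 4 `COc1cccc2c1c(NS(=O)(=O)c1cccc(Cl)c1)nn2Cc1cccc(CNC(=O)C(C)(C)O)c1` share another, and the difference between the two cores is not broken down here. In a physicochemical assay for acid dissociation, compound 1 gives 5.93, compound 2 gives 6.03 and compound 3 gives 6.76. Within the first pair the change hydrogen in place of chloro on an aromatic carbon produced a number 0.10 log units lower from compound 2 to compound 1 (within the scatter). Compound 4 arises from compound 3 by hydrogen in place of chloro on an aromatic carbon, the same kind of change, though the surroundings differ: the earlier chloro sat on a ring that is part of a fused or bridged system of two rings, ortho to a fused ring and meta to a fused ring, whereas the chloro now leaving sits ortho to a chloro group and para to a large group. For compound 4 the expected step is a number 0.24 log units higher from compound 3 to compound 4 (within the scatter), a size set beside a number 0.10 log units lower from compound 2 to compound 1 (within the scatter) and resting on that single earlier measurement, with extra width allowed for the changed surroundings. In this assay compound 4 is estimated at 7, expected to fall between 6.6 and 7.4.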

Compound 4, acid dissociation constant: 7.06
Beside the measured number, compound 4's estimate is 0.06 log units below it; the range from low to high includes it.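

In this assay, among the compounds shown here, the replacement of chloro by hydrogen gives a number 0.30 log units higher from compound 3 to compound 4 (within the scatter) and, on the other core, a number 0.10 log units lower from compound 2 to compound 1 (within the scatter), so on both cores the change stays inside the usual scatter of the read-out and no step of consequence has yet appeared in either pair. For the compounds shown here, this does not show that the change transfers as a fixed increment: there are only two pairs, both too small to separate from the scatter, and the chloro leaves a different place in each, in compound 3 ortho to a chloro group and para to a large group, so the same site has not been compared on two cores. No measurement shown bears on what sets these numbers.

The compounds shown leave open whether an amine, a carboxylic acid, a nitrile or a trifluoromethyl group in place of that chloro would move the read-out beyond the scatter. Also open, as far as these compounds go, is whether any such replacement would behave alike on both cores.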